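A single stereocentre inverted on a cyclopropane amide

A few compounds are considered here, and "the series" means these few. Any claim that something is new, unique, unknown or untested is made for them only; others in the source may bear on it.

Measured so far:
compound 1 `COc1cc([C@H]2C[C@]2(CO)C(=O)Nc2ccccc2Cl)cc(OC)c1OC` gives 45500 nM
compound 2 `CCOC(=O)C1(C(=O)Nc2ccc(F)cc2)CC1c1cc(OC)c(OC)c(OC)c1` gives 62400 nM; 36800 nM (2 entries)
compound 3 `CCOC(=O)[C@@]1(C(=O)Nc2ccccc2Cl)C[C@H]1c1cc(OC)c(OC)c(OC)c1` gives 14400 nM

In a functional assay on HeLa cells (Homo sapiens) for cytotoxicity, read by MTT assay, with a stated time of 48 h (on this read-out lower numbers stand for stronger inhibition and higher numbers for weaker inhibition), compound 3 holds the lowest of the two single numbers; its nearest neighbour, compound 1, sits higher by a margin beyond the usual scatter. Compound 2 has several entries rather than one number (the several entries of compound 2 in this assay, 62400 nM; 36800 nM (2 entries)). Among the measured compounds shown here, no step between two measured compounds that differ in one place is available.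

Compound 4 `CCOC(=O)[C@]1(C(=O)Nc2ccccc2Cl)C[C@H]1c1cc(OC)c(OC)c(OC)c1` differs from compound 3 in this way: the two compounds have the same atoms and bonds and differ only in configuration as drawn: 1 of 2 stereo elements differ; a stereocentre at a saturated ring carbon is drawn S in compound 3 and R in compound 4. Nothing measured here shows how such an inversion plays out, so the expected step from compound 3 to compound 4 is a modest one, a 1.5-fold higher number from compound 3 to compound 4 (0.18 log units; within the scatter), toward a higher number, with none beyond the scatter also plausible. Compound 4 is estimated at 22000 nM, within 7000 nM to 65000 nM.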

Compound 4, half-maximal inhibitory concentration: 42400 nM
Beside the measured number, compound 4's estimate is 1.9-fold (0.28 log units) below it, within the range that was stated.
By their numbers in this assay, from the lowest: compound 3; then compounds 4 and 1 (each within the scatter of the next).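

In this assay, among the compounds shown here, the inversion at the saturated ring carbon alone gives a 2.9-fold higher number from compound 3 to compound 4 (0.47 log units; beyond the scatter), the first step here between two compounds that differ in one place. Configuration at this stereocentre therefore registers in the read-out, with the S form as drawn giving the lower number. The step belongs to this stereocentre alone, because of one thing: the fact that compounds 3 and 4 differ only in the configuration as drawn.

Still open, as far as these compounds go, is what inverting the other stereocentre would do. Also open, from the compounds shown here alone, is whether this inversion gives a similar step with a carboxylic acid in place of the ethyl ester.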